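The source may report more compounds than this note shows. Statements on the series, on what has been measured and on what is new or still open speak of the compounds shown alone.

In a functional assay on B16-F10 cells (Mus musculus) for antiproliferative activity, read by MTT assay, with a stated time of 72 h (on this read-out higher numbers stand for weaker inhibition and lower numbers for stronger inhibition), compound 3 (`CCCCCCCCCNC[C@@H]1OC[C@H](N)[C@H]1O`) gives > 128000 nM, which is a limit of the assay and not a number. Compound 1 (`CCCCCCCCNC[C@@H]1OC[C@H](N)[C@@H]1O`) gives > 128000 nM, also a limit. Compound 2 (`CCCCCCCCCCCCNC[C@@H]1OC[C@H](N)[C@H]1O`) gives a true number, 58100 nM. Compound 4 (`CCCCCCCCCCCCCCNC[C@@H]1OC[C@H](N)[C@H]1O`) differs from compound 3 by pentyl in place of hydrogen on a saturated chain carbon, nine bonds along the chain from an amine nitrogen. Among the compounds with values here, only one measured step acts at that place, and it runs the opposite way, with hydrogen replacing propyl in compound 2: an at least 2.2-fold higher number from compound 2 to compound 3 (0.34 log units; beyond the scatter). Since pentyl adds more to the chain than that propyl removes, a lower number is expected in this assay, reaching somewhat past compound 2. The expected step is an at least 6.4-fold lower number from compound 3 to compound 4 (0.80 log units; beyond the scatter). For compound 4 the estimate is 20000 nM, with an expected range of 6000 nM to 60000 nM.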

Compound 4, half-maximal inhibitory concentration: 64300 nM
Estimate against measurement, compound 4: 3.2-fold (0.51 log units) below; the measured number lies above the stated range.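

In this assay pentyl in place of hydrogen on a saturated chain carbon, nine bonds along the chain from an amine nitrogen, gives an at least 1.9-fold lower number from compound 3 to compound 4 (0.29 log units; that floor lies within the scatter) and so brings compound 4 to a true number. Ethyl in place of hydrogen on a saturated chain carbon gives a 1.1-fold higher number from compound 2 to compound 4 (0.04 log units; within the scatter) and so leaves the two compounds indistinguishable. The first step is only a floor because compound 3 stands at a limit: the limit of > 128000 nM in this assay, at which 2 of the 4 values shown sit. The compounds shown leave open whether a longer chain than that of compound 4 would change the read-out, and what an amine or a carboxylic acid at the chain end would do.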